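Fluorine Removal on a Nitrophenyl Side Chain

A few compounds are considered here, and "the series" means these few. Any claim that something is new, unique, unknown or untested is made for them only; others in the source may bear on it.

Compound 1 `Nc1nc(N)c(CCCNc2cc(F)ccc2[N+](=O)[O-])c(O)n1` and compound 2 `Nc1nc(N)c(CCCNc2cc(F)cc(F)c2[N+](=O)[O-])c(O)n1` carry a nitrophenyl side chain; compound 3 `CC(C)(C)OC(=O)CCC(Nc1ccc(CN(CCCc2c(N)nc(N)nc2O)c2cc(F)cc(F)c2[N+](=O)[O-])cc1)C(=O)OC(C)(C)C` and the unmeasured compound 4 `CC(C)(C)OC(=O)CCC(Nc1ccc(CN(CCCc2c(N)nc(N)nc2O)c2cc(F)ccc2[N+](=O)[O-])cc1)C(=O)OC(C)(C)C` carry a much larger one, and the difference between the core of compound 2 and that of compound 3 is not broken down here. In a functional assay on CCRF-CEM cells (Homo sapiens) for cytotoxicity, in the absence of a further agent (on this read-out lower numbers stand for stronger inhibition and higher numbers for weaker inhibition), compound 2 gives 97000 nM. Compound 1 gives > 100000 nM in this assay, a value that is only a limit, sitting at the limit of > 100000 nM in this assay, at which 1 of the 3 values shown sits. The change hydrogen in place of fluoro on an aromatic carbon therefore appears as an at least 1.0-fold higher number from compound 2 to compound 1 (0.01 log units; that floor lies within the scatter). Compound 3 gives 2400 nM in this assay. The same change, (hydrogen in place of fluoro on an aromatic carbon), leads to compound 4. Because an at least 1.0-fold higher number from compound 2 to compound 1 (0.01 log units; that floor lies within the scatter) was seen, compound 4 is expected to show a step of a 1.3-fold higher number from compound 3 to compound 4 (0.10 log units; within the scatter). Compound 4 is accordingly estimated at 3000 nM, between 1200 nM and 8000 nM.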

Compound 4, half-maximal inhibitory concentration: 12000 nM
The estimate for compound 4 lay 4.0-fold (0.60 log units) below the measured number; measured number outside the range, above it.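

In this assay, hydrogen in place of fluoro, read here as 3,5-difluoro-2-nitrophenyl to 5-fluoro-2-nitrophenyl, gives a 5.0-fold higher number from compound 3 to compound 4 (0.70 log units; beyond the scatter), a step that can be read on this larger side chain. Set beside the same change on the other core, this does not show whether the step carries over at a similar size or differs between the cores: the same change on two cores in this assay, an at least 1.0-fold higher number (0.01 log units; that floor lies within the scatter) from compound 2 to compound 1 and a 5.0-fold higher number (0.70 log units; beyond the scatter) from compound 3 to compound 4; the limit leaves it open whether they differ. The value of compound 1 is a limit and not a number: the limit of > 100000 nM in this assay, at which 1 of the 4 values shown sits.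

The compounds shown leave open how the step would behave with an amine in place of the nitro group. They also leave open whether it would persist with free carboxylic acids in place of the two tert-butyl esters.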